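Vero cytotoxicity: ester replaced by amide on the linker

The source may hold more compounds than are shown below. What is called first, only, known or untested is meant among the compounds shown, and "the series" means these compounds.

Measured so far:
compound 1 `CCCC(=O)OC1CCC(CN2CCN(c3cc(=O)c4cc(C(F)(F)F)cc([N+](=O)[O-])c4s3)CC2)CC1` — > 64 ug/mL
compound 2 `O=C(OC1CCC(CN2CCN(c3cc(=O)c4cc(C(F)(F)F)cc([N+](=O)[O-])c4s3)CC2)CC1)c1ccc(F)cc1` — > 64 ug/mL
compound 3 `O=C(OC1CCC(CN2CCN(c3cc(=O)c4cc(C(F)(F)F)cc([N+](=O)[O-])c4s3)CC2)CC1)c1ccncc1` — > 64 ug/mL

In an ADME assay on Vero cells (Chlorocebus sabaeus) for cytotoxicity, read by MTT assay, with a stated time of 48 h (a higher number here means a weaker inhibitor, a lower number a stronger inhibitor), compound 1 gives > 64 ug/mL, which is a limit of the assay and not a number. Compound 2 gives > 64 ug/mL, also a limit. Compound 3 gives > 64 ug/mL, again a limit. Compound 1 therefore stands at the top of the range tested, together with the other two, as the limit of > 64 ug/mL in this assay, at which 3 of the 3 values shown sit, shows. The steps among the three, a step that the two limits leave unreadable from compound 1 to compound 2, a step that the two limits leave unreadable from compound 1 to compound 3 and a step that the two limits leave unreadable from compound 2 to compound 3, cannot be read in size or direction, since every value is a limit.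

Compound 4 is `O=C(NC1CCC(CN2CCN(c3cc(=O)c4cc(C(F)(F)F)cc([N+](=O)[O-])c4s3)CC2)CC1)c1ccccc1`. Its change from compound 1 is benzamido in place of (propylcarbonyl)oxy on a saturated ring carbon. Among the compounds with values here, no measured step varies the link between the carbonyl and the saturated ring; the measured steps only exchange the group on the carbonyl carbon, and all three compounds stay at the limit. Compound 4 is therefore expected to remain at the limit as well, with the step that the limit leaves unreadable from compound 1 to compound 4 expected to show nothing beyond the scatter. The estimate for compound 4 in this assay is 90 ug/mL, within 45 ug/mL to 200 ug/mL.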

Compound 4, half-maximal inhibitory concentration: 44.3 ug/mL
Beside the measured number, compound 4's estimate is 2.0-fold (0.31 log units) above it; the measured number lies below the stated range.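

In this assay compound 4 is the only compound shown with a number rather than a limit, 44.3 ug/mL, which gives this saturated ring carbon its first steps with a direction: an at least 1.4-fold lower number from compound 1 to compound 4 (0.15 log units; that floor lies within the scatter), an at least 1.4-fold lower number from compound 2 to compound 4 (0.15 log units; that floor lies within the scatter) and an at least 1.4-fold lower number from compound 3 to compound 4 (0.15 log units; that floor lies within the scatter). These are floors, and a floor alone does not separate compound 4 from the other three compounds. Benzamido also changes both the link to the ring and the group on the carbonyl carbon, so the steps cannot be assigned to the amide link alone, and the other compounds remain at a limit: the limit of > 64 ug/mL in this assay, at which 3 of the 4 values shown sit.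

The steps among compound 1, compound 2 and compound 3 cannot be read, leaving the role of the group on the carbonyl carbon open. Also open, on these data alone, is how a butanamide, a benzoate ester, a sulfonamide or a free amine on this ring carbon would read in this assay.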